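Ethylcarbamoyl variant of compound 1: expected potency

The source may hold more compounds than are shown below. What is called first, only, known or untested is meant among the compounds shown, and "the series" means these compounds.

Measured so far in a functional assay on HT-29 cells (Homo sapiens) for antiproliferative activity, read by MTT assay, with a stated time of 72 h; on this read-out lower numbers stand for stronger inhibition and higher numbers for weaker inhibition:
compound 1 `CNC(=O)c1cc(Oc2ccc(NC(=O)c3cc4cccnc4n(-c4ccc(Br)cc4)c3=O)cc2)ccn1` gives 1180 nM;
compound 2 `CNC(=O)c1cc(Oc2ccc(NC(=O)c3cc4cccnc4n(-c4ccc(Br)cc4F)c3=O)cc2)ccn1` gives 1950 nM.

Within the data shown here, compound 1 carries the smaller of the two numbers, yet the only step, a 1.7-fold higher number from compound 1 to compound 2 (0.22 log units; within the scatter), lies within the scatter, so the pair is not truly separated. Compound 3 `CCNC(=O)c1cc(Oc2ccc(NC(=O)c3cc4cccnc4n(-c4ccc(Br)cc4)c3=O)cc2)ccn1` differs from compound 1 by methyl in place of hydrogen on a saturated chain carbon bound to an amide-type nitrogen. Among the measured compounds shown here, no measured step touches this part of the molecule; the one known step concerns a fluoro on an aromatic carbon and has no bearing here. With nothing arguing for a shift, the expected change a 1.1-fold higher number from compound 1 to compound 3 (0.04 log units; within the scatter) is none beyond the scatter. Compound 3 is estimated at 1300 nM, range 500 nM to 3500 nM.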

Compound 3, half-maximal inhibitory concentration: 1160 nM
Estimate against measurement, compound 3: 1.1-fold (0.05 log units) above; the range from low to high includes it.
By their numbers in this assay, from the lowest: compounds 3, 1 and 2 (each within the scatter of the next).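

Methylcarbamoyl to ethylcarbamoyl is the first change read at this position, and in this assay it gives a 1.0-fold lower number from compound 1 to compound 3 (0.01 log units; within the scatter) with the shared core unchanged. A methyl on the saturated chain carbon bound to the amide-type nitrogen therefore leaves the number within the scatter. Nothing measured here accounts for this flat step.

As far as these compounds go, whether a longer chain, such as propyl or butyl, is accepted in the same way stays open. So does the effect of an amine or a carboxylic acid at the end of that chain.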